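The source may report more compounds than this note shows. Statements on the series, on what has been measured and on what is new or still open speak of the compounds shown alone.

In a functional assay on mitochondria from heart for inhibition of peroxisomal acyl-coenzyme A oxidase 1 (Rattus norvegicus) (on this read-out higher numbers stand for weaker inhibition and lower numbers for stronger inhibition), three compounds built on one shared core have been measured. Compound 1 `Cc1nc2cc(OC[C@H](O)CN3CCN(Cc4noc(-c5ccc(C(C)(C)C)cc5)n4)CC3)ccc2s1` gives 180 nM. Compound 2 `Cc1nc2cc(OC[C@H](O)CN3CCN(Cc4noc(-c5ccc(C(F)(F)F)cc5)n4)CC3)ccc2s1` gives 380 nM. Compound 3 `Cc1nc2cc(OC[C@H](O)CN3CCN(Cc4noc(-c5ccc(Cl)c(Cl)c5)n4)CC3)ccc2s1` gives 550 nM. Where compound 3 stands is told by two steps: a 3.1-fold higher number from compound 1 to compound 3 (0.49 log units; beyond the scatter), and a 1.4-fold higher number from compound 2 to compound 3 (0.16 log units; within the scatter); so compound 3 sits clearly apart from compound 1 but cannot be separated from compound 2.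

Compound 4 `Cc1nc2cc(OC[C@H](O)CN3CCN(Cc4noc(-c5ccc(Cl)cc5Cl)n4)CC3)ccc2s1` differs from compound 3 by 2,4-dichlorophenyl in place of 3,4-dichlorophenyl on an aromatic carbon. Going by the values given here, no measured step bears directly on this change: each measured step exchanges the whole group on the aryl ring, and the only step between two chlorine-bearing groups, a 1.4-fold higher number from compound 2 to compound 3 (0.16 log units; within the scatter), stays within the scatter. Compound 4 is therefore expected to show a step of a 1.1-fold higher number from compound 3 to compound 4 (0.04 log units; within the scatter) in this assay, with no direction that can be argued from the measured compounds. For compound 4 the estimate is 600 nM, with a range from 250 nM to 1400 nM.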

Compound 4, half-maximal inhibitory concentration: 130 nM
For compound 4 the middle estimate is 4.6-fold (0.66 log units) above the measured one; measured number outside the range, below it.
By their numbers in this assay, from the lowest: compounds 4 and 1 (each within the scatter of the next); then compounds 2 and 3 (each within the scatter of the next).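

In this assay the two chlorines on this aryl group are not interchangeable in their placement: with the same atoms joined differently, 2,4-dichlorophenyl in place of 3,4-dichlorophenyl gives a 4.2-fold lower number from compound 3 to compound 4 (0.63 log units; beyond the scatter) and so marks the largest step among these compounds. The same group gives a 2.9-fold lower number from compound 2 to compound 4 (0.47 log units; beyond the scatter) and also a 1.4-fold lower number from compound 1 to compound 4 (0.14 log units; within the scatter), which means that compound 1, with its tert-butyl group, no longer stands alone at the low end of the series and that a dichlorophenyl group can share that end with it. Nothing at hand explains why moving one chlorine changes the number so much.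

On these data alone, whether the gain belongs to chlorine itself or to the placement alone stays open, and a difluorophenyl or a dimethoxyphenyl group with its two substituents in the same places as in compound 4 would separate the two. A phenyl ring carrying a single chlorine would show whether both chlorines are needed at all.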